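A few compounds are considered here, and "the series" means these few. Any claim that something is new, unique, unknown or untested is made for them only; others in the source may bear on it.

Three related compounds were tested in a functional assay on C6 cells (Rattus norvegicus) for cytotoxicity, read by MTT assay, with a stated time of 24 h, tested at 12 ug/mL; a higher number here means a weaker effect of the compound at the concentration tested, a lower number a stronger effect. Compound 1 `Cc1nnc(SCC(=O)N/N=c2/scc(-c3ccc(F)cc3)n2-c2ccccc2)s1` gives 73.7%, compound 2 `Cc1ccc(-c2cs/c(=N/NC(=O)CSc3ncccn3)n2-c2ccccc2)cc1` gives 83% and compound 3 `O=C(CSc1ncccn1)N/N=c1/scc(-c2ccc(F)cc2)n1-c1ccccc1` gives 77.4%. All three numbers lie within the usual scatter of one another, so no order among them can be read from these results. Two single changes connect them. From compound 3 to compound 1 the change is 5-methyl-1,3,4-thiadiazol-2-yl in place of pyrimidin-2-yl on a sulfur, and the step that went with it is a number 3.7 percentage points lower from compound 3 to compound 1 (within the scatter). Compound 2 differs from compound 3 by methyl in place of fluoro on an aromatic carbon, and in this assay the step is a number 5.6 percentage points lower from compound 2 to compound 3 (within the scatter).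

Compound 4 `Cc1ccc(-c2cs/c(=N/NC(=O)CSc3nnc(C)s3)n2-c2ccccc2)cc1` is not yet measured. It differs from compound 2 by 5-methyl-1,3,4-thiadiazol-2-yl in place of pyrimidin-2-yl on a sulfur, the same change as that from compound 3 to compound 1, made on a core that differs only by methyl in place of fluoro on an aromatic carbon. Because the earlier step of a number 3.7 percentage points lower from compound 3 to compound 1 (within the scatter) stayed within the scatter, a step of about the same small size is expected here, namely a number 3.5 percentage points lower from compound 2 to compound 4 (within the scatter). Compound 4 is therefore estimated at 79.5%, with a likely range from 70% to 89%.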

Compound 4, a percentage reported as activity, at one concentration (the size of the read-out at that concentration, not a potency): 58.3%
For compound 4 the middle estimate is 21.2 percentage points above the measured one, outside the stated range (below it).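

In this assay, placing 5-methyl-1,3,4-thiadiazol-2-yl instead of pyrimidin-2-yl on the sulfur of the methyl-bearing core gives a number 24.7 percentage points lower from compound 2 to compound 4 (beyond the scatter), so this change did not carry over with the same size from the fluoro-bearing core: the same change on two cores in this assay, a number 3.7 percentage points lower (within the scatter) from compound 3 to compound 1 and a number 24.7 percentage points lower (beyond the scatter) from compound 2 to compound 4, 21 percentage points apart, beyond the scatter of two such steps The same four compounds can be read the other way, since methyl in place of fluoro on an aromatic carbon gives a number 15.4 percentage points lower from compound 1 to compound 4 (beyond the scatter), and this step also depends on the group on the sulfur: the same change on two cores in this assay, a number 5.6 percentage points lower (within the scatter) from compound 2 to compound 3 and a number 15.4 percentage points higher (beyond the scatter) from compound 4 to compound 1, 21 percentage points apart, beyond the scatter of two such steps The two changes therefore do not simply add up in these four compounds, and the stronger effect appears only where methyl and 5-methyl-1,3,4-thiadiazol-2-yl occur together, but one such set cannot show why this happens or establish a rule for the wider series.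

As far as these compounds go, it remains open whether the same dependence would appear with chloro or methoxy in place of methyl or fluoro on the aromatic carbon. It is equally open whether a plain phenyl or pyridin-2-yl on the sulfur would behave like either of the two groups shown.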